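The source may report more compounds than this note shows. Statements on the series, on what has been measured and on what is new or still open speak of the compounds shown alone.

Measured in a functional assay on DU-145 cells (Homo sapiens) for antiproliferative activity, read by WST assay, with a stated time of 3 days; on this read-out lower numbers stand for stronger inhibition and higher numbers for weaker inhibition:
- Compound 1 `CCC(C)Oc1c(-c2cc(OC)c(OC)c(OC)c2)oc2ccccc2c1=O`: > 50000 nM, a limit
- Compound 2 `CCN(CC)CCCOc1c(-c2cc(OC)c(OC)c(OC)c2)oc2ccccc2c1=O`: > 50000 nM, a limit
- Compound 3 `CCN(CC)CCCCOc1c(-c2cc(OC)c(OC)c(OC)c2)oc2ccccc2c1=O`: 13300 nM

Among the compounds with values here, compound 3, at 13300 nM, carries the only number. The remaining values stand at the limit of > 50000 nM in this assay, at which 2 of the 3 values shown sit.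

Compound 4 `CCCN(CCC)CCCCCOc1c(-c2cc(OC)c(OC)c(OC)c2)oc2ccccc2c1=O` differs from compound 3 by (dipropylamino)methyl in place of diethylamino on a saturated chain carbon, four bonds along the chain from an oxygen on an aromatic ring. In words, this is (dipropylamino)methyl in place of diethylamino on a saturated chain carbon, four bonds along the chain from an oxygen on an aromatic ring.

The closest measured change is an at least 3.7-fold lower number from compound 2 to compound 3 (0.57 log units; beyond the scatter), which put (diethylamino)methyl in place of diethylamino and lies beyond the scatter. The change an at least 3.7-fold lower number from compound 1 to compound 3 (0.57 log units; beyond the scatter) points the same way, while a step that the two limits leave unreadable from compound 1 to compound 2 adds nothing readable. Within the data shown here, no measured step covers the change to dipropylamino, so the expectation rests on that single chain step, an at least 3.7-fold lower number from compound 2 to compound 3 (0.57 log units; beyond the scatter).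

A modest further fall in this assay is expected, an estimated 2.7-fold lower number from compound 3 to compound 4 (0.42 log units; beyond the scatter).

For compound 4 the estimate is 5000 nM, with an expected range of 1500 nM to 17000 nM.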

Compound 4, half-maximal inhibitory concentration: 24200 nM
The estimate for compound 4 lay 4.8-fold (0.68 log units) below the measured number; the measured number lies above the stated range.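

In this assay, a 1.8-fold higher number from compound 3 to compound 4 (0.26 log units; within the scatter), so the move to (dipropylamino)methyl at this chain carbon leaves compound 4 level with compound 3 and does not extend the earlier gain from the chain step. The 5-(dipropylamino)pentyl group still keeps a measurable number, with an at least 2.0-fold lower number from compound 2 to compound 4 (0.31 log units; beyond the scatter) and an at least 2.0-fold lower number from compound 1 to compound 4 (0.31 log units; beyond the scatter). The values of compound 1 and compound 2 are limits of the assay, and the step between them cannot be read: the limit of > 50000 nM in this assay, at which 2 of the 4 values shown sit.

On these data alone, compound 4 alters the chain and the amine end together, so the contribution of each stays open; a 5-(diethylamino)pentyl or a 4-(dipropylamino)butyl group would separate them. As far as these compounds go, how a smaller dimethylamino end or a still longer chain would read in this assay also stays open.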